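The source may hold more compounds than are shown below. What is called first, only, known or untested is meant among the compounds shown, and "the series" means these compounds.

Of the compounds shown here, three have been tested in a functional assay on HeLa cells (Homo sapiens) for antiproliferative activity, read by MTT assay, with a stated time of 72 h; a higher number here means a weaker inhibitor, a lower number a stronger inhibitor. Compound 1 `O=C1COc2ccc(-c3cccc(NS(=O)(=O)c4ccc(F)cc4)c3)cc2N1` gives a value that is only a limit of the assay, > 40000 nM. Compound 2 `COc1ncc(-c2ccc3c(c2)NC(=O)CO3)cc1NS(=O)(=O)c1ccc(F)cc1`, which carries a different core, gives 7110 nM. How the core of compound 1 differs from the core of compound 2 is not broken down here. Compound 3 `COc1cccc(N2C(=O)COc3ccc(-c4cnc(OC)c(NS(=O)(=O)c5ccc(F)cc5)c4)cc32)c1` is compound 2 with one change (3-methoxyphenyl in place of hydrogen on an amide-type nitrogen in a ring), and in this assay compound 3 also gives only a limit of the assay, > 40000 nM. That change therefore cost activity: an at least 5.6-fold higher number from compound 2 to compound 3 (0.75 log units; beyond the scatter).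

Compound 4 `COc1cccc(N2C(=O)COc3ccc(-c4cccc(NS(=O)(=O)c5ccc(F)cc5)c4)cc32)c1` has not yet been measured. It is compound 1 with the same change, (3-methoxyphenyl in place of hydrogen on an amide-type nitrogen in a ring), and the place of the change is the same as between compound 2 and compound 3. Two points guide the expectation. First, compound 1 already sits at the limit of > 40000 nM in this assay, at which 2 of the 3 values shown sit, so there is no measured number for it to move from. Second, the same change made compound 3 weaker than compound 2 by an at least 5.6-fold higher number from compound 2 to compound 3 (0.75 log units; beyond the scatter). On that basis compound 4 is expected to remain at or beyond the limit in this assay, with an estimated value of 80000 nM and a plausible span from 40000 nM to 200000 nM. Relative to the limit of compound 1, the expected step is a step that the limit leaves unreadable from compound 1 to compound 4, so the most likely outcome is that the assay again reports only a limit for compound 4.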

Compound 4, half-maximal inhibitory concentration: > 40000 nM
Compound 4: only a limit was reported; the forecaster's own chance of this, stated with the estimate: 90%; the middle value lies beyond the limit too.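

Compound 1 and compound 4 both give only a limit in this assay, so no size can be put on the step between them, because neither value is a true number: the limit of > 40000 nM in this assay, at which 3 of the 4 values shown sit.

The compounds shown leave open how active compound 1 and compound 4 really are, and so whether adding 3-methoxyphenyl on the amide-type nitrogen changes anything on the core of compound 1.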